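Benzyl for 4-ethoxyphenyl on the amine nitrogen

The compounds below may be only part of what the source reports. "The series", "measured", "known", "first", "only" and "open" are said of these compounds alone.

The series is followed in a functional assay on MCF7 cells (Homo sapiens) for inhibition, read by sulforhodamine B assay; on this read-out higher numbers stand for weaker inhibition and lower numbers for stronger inhibition. Compound 1 `O=C1C(N2CCCC2)=CC(=O)c2c1nc1n2[C@H]2OC[C@@H](O)[C@H]2OC1` gives > 16000 nM, which is a limit and not a number. Compound 2 `CCOc1ccc(NC2=CC(=O)c3c(nc4n3[C@H]3OC[C@@H](O)[C@H]3OC4)C2=O)cc1` gives > 4000 nM, which is also a limit. Compound 2 therefore has no numerical place in the series. Going by the values given here, with only limits available, no step between these two compounds can be read.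

Compound 3 `O=C1C(NCc2ccccc2)=CC(=O)c2c1nc1n2[C@H]2OC[C@@H](O)[C@H]2OC1` keeps the core of compound 2 and carries benzyl in place of 4-ethoxyphenyl on an amine nitrogen. A six-membered aromatic ring of carbon only stands on both sides of the change.

In this assay, the expected step that the limit leaves unreadable from compound 2 to compound 3 stays within the usual scatter, and no direction is favoured. This expectation rests on compound 2, with its limit of > 4000 nM. A report of compound 3 as a limit would also be no surprise. Compound 3 is estimated at 6000 nM, with an expected range from 2000 nM to 20000 nM.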

Compound 3, half-maximal inhibitory concentration: > 8000 nM
Compound 3 was reported as a limit (the forecaster's own chance of this, stated with the estimate: 55%); at least 1.3-fold (0.12 log units) between middle value and limit.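

In this assay compound 3 gives > 8000 nM, which is a limit, and the steps linking compound 3 to compound 1 and to compound 2 cannot be read. The compounds shown leave open whether benzyl, 4-ethoxyphenyl and pyrrolidin-1-yl differ at all in their effect on this read-out.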